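Trading ethylsulfanyl for methyl on the shared core

A few compounds are considered here, and "the series" means these few. Any claim that something is new, unique, unknown or untested is made for them only; others in the source may bear on it.

Compound 1 `CCc1nc(N)c2nc(O)n(Cc3ccccc3)c2n1`: 1 uM
Compound 2 `CSc1nc(N)c2nc(O)n(Cc3ccccc3)c2n1`: 0.1 uM
Compound 3 `CCSc1nc(N)c2nc(O)n(Cc3ccccc3)c2n1`: 0.1 uM
Compound 4 `Cc1nc(N)c2nc(O)n(Cc3ccccc3)c2n1`: not yet measured

In a functional assay (spleen, spleen) for activation, with Mus musculus as the target (a higher number here means that more compound is needed for the effect, a lower number that less compound is needed), compound 3 gives 0.1 uM, level with compound 2 at the digits shown and together the lowest of the three numbers; the step of a 10-fold lower number from compound 1 to compound 3 (1.00 log units; beyond the scatter) separates it from compound 1. Compound 4 differs from compound 3 by methyl in place of ethylsulfanyl on an aromatic carbon. Going by the values given here, no measured step carries a methyl, so the nearest guide is a 10-fold lower number from compound 1 to compound 3 (1.00 log units; beyond the scatter), read in reverse: the ethyl of compound 1 went with the higher number. The step of no change at the digits printed from compound 2 to compound 3 (within the scatter) stays within the scatter, so the sulfur-bearing group, not its length, goes with the low numbers. With the ethylsulfanyl leaving, the expected step is a 15-fold higher number from compound 3 to compound 4 (1.18 log units; beyond the scatter). Compound 4 is estimated at 1.5 uM, within 0.4 uM to 6 uM.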

Compound 4, minimum effective concentration: 1 uM
Compound 4: the middle estimate sits 1.5-fold (0.18 log units) above what was measured, within the range that was stated.
By their numbers in this assay, from the lowest: compounds 2 and 3 (each within the scatter of the next); then compounds 1 and 4 (each within the scatter of the next).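

In this assay, a sulfur-linked group at this position goes with the low number against methyl as well as against ethyl: a 10-fold higher number from compound 3 to compound 4 (1.00 log units; beyond the scatter), and a 10-fold higher number from compound 2 to compound 4 (1.00 log units; beyond the scatter). Among the groups without sulfur, chain length leaves the number unmoved, with no change at the digits printed from compound 1 to compound 4 (within the scatter). The extra carbon thus reads alike with and without the sulfur: the same change on two cores in this assay, no change at the digits printed (within the scatter) from compound 2 to compound 3 and no change at the digits printed (within the scatter) from compound 4 to compound 1, 1.0-fold (0.00 log units) apart, within the scatter of two such steps

On these data alone, whether methoxy or an amine at this position would go with the low number or the high one remains open. So does whether a longer chain on the sulfur, such as butylsulfanyl, would keep the low number.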